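Dichloroacetanilides: a trifluoromethoxy group in place of bromine

The compounds below may be only part of what the source reports. "The series", "measured", "known", "first", "only" and "open" are said of these compounds alone.

Three dichloroacetamides share a core, and compound 3 `O=C(Nc1cccc(Br)c1)C(Cl)Cl` holds the lowest of the two numbers reported in a functional assay on Bel-7402 cells (Homo sapiens) for antiproliferative activity, read by MTT assay, with a stated time of 72 h (on this read-out higher numbers stand for weaker inhibition and lower numbers for stronger inhibition), where compound 3 gives 7720 nM. Compound 1 `O=C(Nc1ccccc1Br)C(Cl)Cl` stands nearest, and in this assay compound 1 gives 38200 nM, a gap beyond the scatter. For compound 2 `O=C(Nc1ccccc1NC(=O)C(Cl)Cl)C(Cl)Cl` the outcome in this assay is "not determined" (no result reported).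

Compound 4 `O=C(Nc1cccc(OC(F)(F)F)c1)C(Cl)Cl` differs from compound 3 by trifluoromethoxy in place of bromo on an aromatic carbon. Among the measured compounds shown here, no measured pair shows what such a swap does here, so the expectation rests on compound 3 alone. The step from compound 3 to compound 4 is expected to be a 1.3-fold higher number from compound 3 to compound 4 (0.11 log units; within the scatter), a shift within or only slightly beyond the scatter. Compound 4 is estimated at 10000 nM in this assay, with a range from 3000 nM to 35000 nM.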

Compound 4, half-maximal inhibitory concentration: 10300 nM
The estimate for compound 4 lay 1.0-fold (0.01 log units) below the measured number; low and high end bracket the measured number.
By their numbers in this assay, from the lowest: compounds 3 and 4 (each within the scatter of the next); then compound 1.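

In this assay, this place on the aromatic ring proves open to a second group: trifluoromethoxy in place of bromo gives a 1.3-fold higher number from compound 3 to compound 4 (0.13 log units; within the scatter) and so leaves the read-out unchanged, despite the larger group and its added hydrogen-bond acceptor. Until now only bromo had been seen at this place. Nothing measured here explains why the two groups match.

Going by these compounds, it remains open whether an amine, a carboxylic acid or a longer alkyl chain at this place would give a similar number.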